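A few compounds are considered here, and "the series" means these few. Any claim that something is new, unique, unknown or untested is made for them only; others in the source may bear on it.

Measured compounds:
Compound 1 `Cn1cc(/C=C(\C#N)S(C)(=O)=O)c2ccccc21`: in a functional assay on MT4 cells (Homo sapiens) for antiproliferative activity, read by MTT assay, with a stated time of 96 h (on this read-out higher numbers stand for an effect only at larger amounts of compound and lower numbers for an effect already at smaller amounts), compound 1 gives > 100000 nM, which is a limit of the assay and not a number.
Compound 2 `COc1ccc(-c2[nH]c3ccc(OC)cc3c2/C=C(\C#N)S(=O)(=O)c2ccccc2)cc1`: in this assay compound 2 gives 200 nM.
Compound 3 `N#C/C(=C\c1c(-c2ccccc2)[nH]c2ccccc12)C(=O)N1CCCCC1`: in this assay compound 3 gives 9600 nM.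

Of the two compounds that give an actual number, compound 3 stands highest; compound 2 sits far lower, by a margin well beyond the usual scatter. The third result, that of compound 1, is the limit of > 100000 nM in this assay, at which 1 of the 3 values shown sits.

Compound 4 `N#C/C(=C\c1c(-c2ccccc2)[nH]c2ccccc12)S(=O)(=O)c1ccccc1` has not yet been measured. It is reached from compound 3 by a single change: phenylsulfonyl in place of (piperidin-1-yl)carbonyl on a double-bonded chain carbon bound to a double-bonded chain carbon and a triple-bonded carbon. Within the data shown here, no measured pair shows this exact change, so its size cannot be read off directly. Compound 2 does carry a phenylsulfonyl on its chain and gives the lowest number of the set, but compound 2 also carries methoxy groups that compound 4 lacks, so the two are not a clean comparison. On that background compound 4 is expected to land below compound 3, with a step of a 6.4-fold lower number from compound 3 to compound 4 (0.81 log units; beyond the scatter) that is estimated to exceed the scatter but not to reach the number of compound 2. The estimate for compound 4 is 1500 nM, with a range from 300 nM to 8000 nM.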

Compound 4, half-maximal effective concentration: 400 nM
Estimate against measurement, compound 4: 3.8-fold (0.57 log units) above, and the stated range covers the measured number.
By their numbers in this assay, from the lowest: compounds 2 and 4 (each within the scatter of the next); then compound 3. At a limit, above all of these: compound 1.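

In this assay, among these compounds, putting phenylsulfonyl in place of (piperidin-1-yl)carbonyl gives a 24-fold lower number from compound 3 to compound 4 (1.38 log units; beyond the scatter), the only step in this set that can be read between two compounds differing in one place. It shows that this position, on a double-bonded chain carbon bound to a double-bonded chain carbon and a triple-bonded carbon, is not indifferent to what sits on it: with the rest of the structure unchanged, the exchange of this one group moves the number well beyond the scatter. Nothing on record speaks to why the step has this size, and the one limit in the set does not bear on it.

On these data alone, it remains open whether the step follows the sulfonyl link or the ring that comes with it, a question that a benzoyl group at this place, joining an aromatic ring through a carbonyl, would bear on directly. Also open, as far as these compounds go, is how an ethyl ester or a carboxylic acid would fare on the same carbon, and how a chlorine on the phenyl ring of phenylsulfonyl would shift the number.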